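Swapping a Ring for an Amide on a Shared Core

The compounds below may be only part of what the source reports. "The series", "measured", "known", "first", "only" and "open" are said of these compounds alone.

Compound 1, whose structure is `Clc1ccc(Nc2nc3ccc(N4CCCC4)cc3nc2Nc2ccc(Cl)c(Cl)c2)cc1Cl`, has no single number in this study: in a toxicity assay on HepG2 cells (Homo sapiens) for cytotoxicity, read by MTT assay, with a stated time of 24 h (on this read-out lower numbers stand for higher toxicity in this test and higher numbers for lower toxicity in this test), compound 1 is reported as "nd" (no result reported), so nothing can be said of where it stands on this read-out. A related compound, compound 2 with structure `O=[N+]([O-])c1ccc2nc(Nc3ccc(F)cc3)c(Nc3ccc(F)cc3)nc2c1`, is the only one here that carries a value; in this assay compound 2 gives 10200 nM. The unmeasured compound 3, with structure `CC(=O)Nc1ccc2nc(Nc3ccc(Cl)c(Cl)c3)c(Nc3ccc(Cl)c(Cl)c3)nc2c1`, differs from compound 1 in one place, (acetamido in place of pyrrolidin-1-yl on an aromatic carbon). Among the compounds with values here, no step between measured compounds is available, and the two values that would define a step from compound 1 to compound 3 are not both known, so the direction cannot be read from data. Given that a substituent of similar size, here acetamido in place of pyrrolidin-1-yl on an aromatic carbon, is exchanged on the same core, a change within the usual scatter is expected rather than a large one in either direction. Compound 3 is expected to give about 9000 nM in this assay, estimated to fall between 2500 nM and 32000 nM.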

Compound 3, half-maximal cytotoxic concentration: 8600 nM
Compound 3: middle estimate off by 1.0-fold (0.02 log units), on the high side, and the stated range covers the measured number.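

No step can be read from compound 1 to compound 3: in this assay compound 3 gives 8600 nM and compound 1 has no single number. The compounds shown leave open how acetamido in place of pyrrolidin-1-yl on the shared core shifts this read-out. Nothing available bears on a cause for the value of compound 3.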